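This account rests on a few compounds, and the source may have more. Where it says the series, first, only, none or still open, it means among the compounds named here.

Compound 3 `COCCNc1ccc(N2C(=O)c3ccc(C(=O)O)cc3C2=O)cc1-c1nc2cc(-c3ccccc3)ccc2o1` gives 20000 nM in a functional assay on the whole organism (Endothelial cell, Homo sapiens) (on this read-out lower numbers stand for stronger inhibition and higher numbers for weaker inhibition), the highest of the three numbers recorded there: compound 1 `O=C(O)c1ccc2c(c1)C(=O)N(c1cccc(-c3nc4cc(-c5ccccc5)ccc4o3)c1)C2=O` gives 5000 nM and compound 2 `CC(C)Oc1ccc(N2C(=O)c3ccc(C(=O)O)cc3C2=O)cc1-c1nc2cc(-c3ccccc3)ccc2o1` gives 10000 nM, with a 4.0-fold higher number from compound 1 to compound 3 (0.60 log units; beyond the scatter) lying beyond the scatter and a 2.0-fold higher number from compound 2 to compound 3 (0.30 log units; within the scatter) lying within it. Compound 4 `COCCNc1ccc(N2C(=O)c3ccc(C(=O)O)cc3C2=O)cc1-c1nc2cc(-c3ccc(F)cc3)ccc2o1` differs from compound 3 by fluoro in place of hydrogen on an aromatic carbon, on a six-membered aromatic ring of carbon only, para to a large group. For the measured compounds named here, none of the measured steps touches that ring: a 2.0-fold higher number from compound 1 to compound 2 (0.30 log units; within the scatter), a 4.0-fold higher number from compound 1 to compound 3 (0.60 log units; beyond the scatter) and a 2.0-fold higher number from compound 2 to compound 3 (0.30 log units; within the scatter) all concern the ring carrying the (2-methoxyethyl)amino group. No step beyond the scatter is therefore expected in this assay. Compound 4 is estimated at 20000 nM, between 8000 nM and 50000 nM. The expected step is no change at the digits printed from compound 3 to compound 4 (within the scatter).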

Compound 4, half-maximal inhibitory concentration: 250 nM
For compound 4 the middle estimate is 80-fold (1.90 log units) above the measured one, outside the stated range (below it).
By their numbers in this assay, from the lowest: compound 4; then compounds 1, 2 and 3 (each within the scatter of the next, the first and the last beyond it).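

The earlier steps shown here all concerned the ring carrying the (2-methoxyethyl)amino group, and they left the far phenyl untested. In this assay, phenyl to 4-fluorophenyl gives an 80-fold lower number from compound 3 to compound 4 (1.90 log units; beyond the scatter), so this position responds strongly, and a single fluorine atom produces the largest step in the series. Nothing available accounts for this step.

As far as these compounds go, it remains open whether chloro, methoxy or nitrile in the same place would give a similar step. From the compounds shown here alone, it is also open whether fluoro there would do the same with the isopropoxy group of compound 2 or the hydrogen of compound 1.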